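This account rests on a few compounds, and the source may have more. Where it says the series, first, only, none or still open, it means among the compounds named here.

Measured so far in a functional assay on SK-MEL-28 cells (Homo sapiens) for inhibition, read by sulforhodamine B assay, with a stated time of 48 h, tested at 10 uM; on this read-out higher numbers stand for a weaker effect at the one concentration tested and lower numbers for a stronger effect:
compound 1 `COc1cc(Cl)cc(-c2nn(-c3cccc(NC(=O)c4ccc(Cl)c(Cl)c4)c3)cc2-c2ccncc2)c1`: 87.8%
compound 2 `O=C(Nc1cccc(-n2cc(-c3ccncc3)c(-c3cc(O)cc(Cl)c3)n2)c1)Nc1ccc(Cl)c(C(F)(F)F)c1`: -13.5%
compound 3 `COc1cc(Cl)cc(-c2nn(-c3cccc(NC(=O)Nc4cc(C(F)(F)F)cc(C(F)(F)F)c4)c3)cc2-c2ccncc2)c1`: 6.55%

Compound 3 stands second highest of the three numbers in this assay. Its nearest neighbour is compound 2, whose number lies lower by a margin beyond the usual scatter; compound 1 is furthest, higher by a margin far beyond the scatter. The two ureas, compound 2 and compound 3, thus sit at the strong end, while the amide, compound 1, shows little effect at the single concentration.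

Compound 4 `COc1cc(Cl)cc(-c2nn(-c3cccc(NC(=O)Nc4cccc(C(F)(F)F)c4)c3)cc2-c2ccncc2)c1` is not yet measured. Against compound 3 it differs in one place: hydrogen in place of trifluoromethyl on an aromatic carbon. One trifluoromethyl remains on that ring.

Among the compounds with values here, no measured pair shows this step, so its size must be guessed. The urea pair, compound 2 and compound 3, both stay low with different substitution on the terminal ring, so a modest move toward a weaker effect is expected rather than a large one, and the step may well stay within the scatter. The step from compound 3 to compound 4 is expected to be a number 13.5 percentage points higher from compound 3 to compound 4 (beyond the scatter). Compound 4 is estimated at 20% in this assay, with a range from -10% to 55%.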

Compound 4, a percentage reported as activity, at one concentration (the size of the read-out at that concentration, not a potency): 14.1%
Compound 4: the middle estimate sits 5.9 percentage points above what was measured, within the range that was stated.
By their numbers in this assay, from the lowest: compound 2; then compounds 3 and 4 (each within the scatter of the next); then compound 1.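

In this assay, hydrogen in place of trifluoromethyl on an aromatic carbon of the terminal ring gives a number 7.6 percentage points higher from compound 3 to compound 4 (within the scatter), so for this pair the second trifluoromethyl is not required to keep the strong effect at the one concentration tested. The other step, (3-(trifluoromethyl)phenyl)amino in place of 3,4-dichlorophenyl on a carbonyl carbon, gives a number 73.7 percentage points lower from compound 1 to compound 4 (beyond the scatter), which places a large change at this single site and dwarfs the trifluoromethyl step. No supporting data bear on the cause of either step.

From the compounds shown here alone, it remains open whether the remaining trifluoromethyl can also give way to hydrogen without loss of effect. Going by these compounds, it is equally open how an amine, a nitrile or a carboxylic acid would read at either of these two ring positions.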